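This account rests on a few compounds, and the source may have more. Where it says the series, first, only, none or still open, it means among the compounds named here.

Measured so far in a functional assay on NCI-H460 cells (Homo sapiens) for cytotoxicity, read by MTT assay; on this read-out higher numbers stand for weaker inhibition and lower numbers for stronger inhibition:
- compound 1, `Cc1nc(Nc2cccc(Cl)c2)sc1C(=O)/C=C/c1ccc(Cl)cc1`: > 25000 nM, which is a limit of this assay and not a number
- compound 2, `COc1cc(/C=C/C(=O)c2sc(Nc3cccc(C)c3)nc2C)cc(OC)c1OC`: 19800 nM
- compound 3, `Cc1cccc(Nc2nc(C)c(C(=O)/C=C/c3ccccc3)s2)c1`: 21800 nM

Compound 2 has the lowest of the two numbers shown, but its nearest neighbour, compound 3, sits within the scatter of it, so no order between the two can be read. Compound 1 contributes only (the limit of > 25000 nM in this assay, at which 1 of the 3 values shown sits), so it gives no number to compare against. For the measured compounds named here, no pair among the three differs in one place only, and no measured step is therefore available.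

The next compound, compound 4, `COc1cc(/C=C/C(=O)c2sc(Nc3ccc(F)c(Cl)c3)nc2C)cc(OC)c1OC`, is compound 2 with one change: 3-chloro-4-fluorophenyl in place of 3-methylphenyl on a nitrogen on an aromatic ring. Going by the values given here, the only other compound carrying a chlorine on that ring, compound 1, has a different second aryl group, so its limit says nothing about this step on its own.

Among the compounds with values here, with no measured step to rest on and the two numbers within the scatter of each other, the expected step from compound 2 to compound 4 in this assay is a 1.1-fold higher number from compound 2 to compound 4 (0.03 log units; within the scatter), that is none beyond the scatter. Compound 4 is accordingly estimated at 21000 nM, with a range from 8000 nM to 50000 nM, and a fair chance that this assay reports only a limit.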

Compound 4, half-maximal inhibitory concentration: 6310 nM
The estimate for compound 4 lay 3.3-fold (0.52 log units) above the measured number, and the stated range ends above it.
By their numbers in this assay, from the lowest: compound 4; then compounds 2 and 3 (each within the scatter of the next). At a limit, above all of these: compound 1.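

On a nitrogen on an aromatic ring, with the rest of compound 2 held fixed, 3-chloro-4-fluorophenyl in place of 3-methylphenyl in this assay gives a 3.1-fold lower number from compound 2 to compound 4 (0.50 log units; beyond the scatter). The earlier compounds shown here offered no measured step, so this is the only direct sign so far that the group at this position can move the number beyond the scatter, and the step is modest. The change brings in chlorine and fluorine and removes the methyl in a single swap, so the step cannot be divided among them.

Going by these compounds, it remains open whether 3-chlorophenyl or 4-fluorophenyl alone would account for the step, whether it would carry over to the core of compound 3, and how an amine or a carboxylic acid on this ring would read. Compound 1 stands at a limit and not a number, so it adds no step, and the upper end of this series stays unresolved: the limit of > 25000 nM in this assay, at which 1 of the 4 values shown sits.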